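Swapping the Aryl on the Triazole of an Inactive Series

The compounds below may be only part of what the source reports. "The series", "measured", "known", "first", "only" and "open" are said of these compounds alone.

Compound 1 `CC(C)n1ncc2c(C(=O)NCc3cn(-c4ccccc4)nn3)cccc21` gives in a functional assay on MCF7 cells (Homo sapiens) for inhibition, read by MTT assay, with a stated time of 72 h (a lower number here means a stronger inhibitor, a higher number a weaker inhibitor), a limit of > 40000 nM rather than a number.
Compound 2 `CC(C)n1ncc2c(C(=O)NCc3cn(-c4cccc(Br)c4)nn3)cccc21` gives in this assay a limit of > 40000 nM.
Compound 3 `CC(C)n1ncc2c(C(=O)NCc3cn(-c4ccc([N+](=O)[O-])cc4)nn3)cccc21` gives in this assay a limit of > 40000 nM.

Compound 3 thus stands where the other two stand: all three sit at the limit of > 40000 nM in this assay, at which 3 of the 3 values shown sit, and none was potent enough to yield a measurable number. The steps a step that the two limits leave unreadable from compound 1 to compound 2, a step that the two limits leave unreadable from compound 1 to compound 3 and a step that the two limits leave unreadable from compound 2 to compound 3 therefore have no readable size. Compound 4 `CC(C)n1ncc2c(C(=O)NCc3cn(-c4ccccc4F)nn3)cccc21` differs from compound 3 by 2-fluorophenyl in place of 4-nitrophenyl on an aromatic nitrogen. Among the compounds with values here, no measured step can be read for this change; the only guidance is that every variation of the phenyl ring so far left the compound at the limit. Compound 4 is therefore expected to remain at the limit too, with the estimated step of a number no higher from compound 3 to compound 4 (the limit leaves the size open) carrying no readable size. The estimate for compound 4 in this assay is 40000 nM, between 20000 nM and 80000 nM.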

Compound 4, half-maximal inhibitory concentration: > 40000 nM
Compound 4: no number, only a limit; the forecaster's own chance of this, stated with the estimate: 85%; the middle value sits exactly at the limit.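

Compound 4 also gives only a limit, > 40000 nM, so its steps from compound 1, compound 2 and compound 3 cannot be read. Which of the four compounds inhibits more strongly stays open, as does whether any other phenyl substituent would give a measurable value.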